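Hydroxy for dimethylamino on the chain of compound 3

This account rests on a few compounds, and the source may have more. Where it says the series, first, only, none or still open, it means among the compounds named here.

Measured so far:
compound 1 `NCCCNc1cc(N2CCc3ccccc3C2)nc2ccccc12`: 8400 nM
compound 2 `NCC(O)CNc1cc(N2CCCc3ccccc3C2)nc2ccccc12`: 21000 nM
compound 3 `Cc1ccc2nc(N3CCCc4ccc(F)cc4C3)cc(NCCN(C)C)c2c1`: 89000 nM

In an ADME assay on HEp-2 cells (Homo sapiens) for cytotoxicity, read by CCK-8 assay, with a stated time of 5 days (a higher number here means that more compound is tolerated, a lower number that less compound is tolerated), compound 3 gives 89000 nM, the highest of the three numbers. Its nearest neighbour on the numbers is compound 2 with 21000 nM, a gap that lies beyond the scatter, and the furthest is compound 1 with 8400 nM, also beyond the scatter. No pair among these three differs in only one place, so the numbers of compound 1 and compound 2 say nothing direct about the change that follows.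

Compound 4 `Cc1ccc2nc(N3CCCc4ccc(F)cc4C3)cc(NCCO)c2c1` differs from compound 3 in one place: hydroxy in place of dimethylamino on a saturated chain carbon, two bonds along the chain from a nitrogen on an aromatic ring. The chain that carries the group stays, only its end changes.

The step that the estimate means, a 1.6-fold lower number from compound 3 to compound 4 (0.21 log units; within the scatter), is expected to be a modest downward move in this assay, not clearly beyond the scatter. Compound 4 is thus estimated at 55000 nM, with a range from 18000 nM to 160000 nM, so that it likely stays well above compound 1 and compound 2 on these numbers.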

Compound 4, half-maximal cytotoxic concentration: > 100000 nM
Compound 4 gave a limit, no number (the forecaster's own chance of this, stated with the estimate: 15%); middle value at least 1.8-fold (0.25 log units) from the limit.
By their numbers in this assay, from the lowest: compound 1; then compound 2; then compound 3. At a limit, above all of these: compound 4.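

In this assay compound 4 gives > 100000 nM, which is a limit of the assay and not a number. Among these compounds, this is the first comparison here that changes one place only, and it reads an at least 1.1-fold higher number from compound 3 to compound 4 (0.05 log units; that floor lies within the scatter), so hydroxy in place of dimethylamino at this chain end gives no sign of a lower number, although the floor of the step does not establish a rise. How far the step extends stays hidden, and only its floor can be stated: the limit of > 100000 nM in this assay, at which 1 of the 4 values shown sits.

The compounds shown leave open how far compound 4 lies past that limit, so the true size of this change remains unknown. They also leave open whether a methoxy, a carboxylic acid or a longer chain carrying the hydroxy would stay at the limit or return to a measurable number.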